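Working notes on a three-compound cytotoxicity series

A few compounds are considered here, and "the series" means these few. Any claim that something is new, unique, unknown or untested is made for them only; others in the source may bear on it.

Measured so far:
compound 1 `Cn1ccc2c(Oc3ccc(NC(=O)c4nn(-c5ccc(Cl)c(C(F)(F)F)c5)ccc4=O)cc3)ccnc21` — 11400 nM
compound 2 `Cn1ccc2c(Oc3ccc(NC(=O)c4nn(-c5ccccc5)ccc4=O)cc3F)ccnc21` — > 60000 nM

In a functional assay on A549 cells (Homo sapiens) for cytotoxicity, read by MTT assay, with a stated time of 72 h (a higher number here means a weaker inhibitor, a lower number a stronger inhibitor), compound 1 gives 11400 nM. For compound 2 this assay reports only a limit, > 60000 nM, and no number. This is the limit of > 60000 nM in this assay, at which 1 of the 2 values shown sits, so compound 2 stands at the limit end of the two values shown. Among the compounds with values here, compound 1 and compound 2 differ in two places at once, so their two values show only that compound 1 has a measured number where compound 2 has none.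

Compound 3 `Cn1ccc2c(Oc3ccc(NC(=O)c4nn(-c5ccc(Cl)c(C(F)(F)F)c5)ccc4=O)cc3F)ccnc21` differs from compound 2 in one place: 4-chloro-3-(trifluoromethyl)phenyl in place of phenyl on an aromatic nitrogen. Within the data shown here, no measured step covers this change on its own. Compound 1 carries the same 4-chloro-3-(trifluoromethyl)phenyl group and gives 11400 nM in this assay, which is a measured number rather than a limit. The expected at least 4.0-fold lower number from compound 2 to compound 3 (0.60 log units; beyond the scatter) is therefore a move toward stronger inhibition, likely beyond the scatter, though the limit for compound 2 leaves its size open. Compound 3 is estimated at 15000 nM, with a range from 5000 nM to 60000 nM.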

Compound 3, half-maximal inhibitory concentration: 17700 nM
For compound 3 the middle estimate is 1.2-fold (0.07 log units) below the measured one; measured number inside the range.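

In this assay, the change from phenyl to 4-chloro-3-(trifluoromethyl)phenyl on the aromatic nitrogen now has a step of its own, read with the fluoro held constant: an at least 3.3-fold lower number from compound 2 to compound 3 (0.53 log units; beyond the scatter). Going by these compounds, the true size of this step remains unknown, as compound 2 has a limit of the assay and not a number: the limit of > 60000 nM in this assay, at which 1 of the 3 values shown sits. With the 4-chloro-3-(trifluoromethyl)phenyl group held constant, the other change, fluoro in place of hydrogen on an aromatic carbon, gives a 1.6-fold higher number from compound 1 to compound 3 (0.19 log units; within the scatter), so compound 1 and compound 3 cannot be told apart in this assay.

The chloro and the trifluoromethyl enter together in this step, so the compounds shown do not tell how much of it belongs to either group alone, and no pair shows the fluoro change with a plain phenyl on the aromatic nitrogen. Also open, on these data alone, is how a group of a different kind at this position, such as an amine or a carboxylic acid on the phenyl ring, would read in this assay.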